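The source may hold more compounds than are shown below. What is called first, only, known or untested is meant among the compounds shown, and "the series" means these compounds.

Among the measured compounds shown here, in an ADME assay on liver for metabolic stability, with Liver microsome (Homo sapiens) as the target, read by LC-MS, using microsomes (a lower number here means slower removal, a higher number faster removal of the compound), compound 2 `O=C(NCc1cc(Cl)ccc1-n1cnnn1)[C@@H]1CC=NN1C(=O)[C@H](O)c1ccccc1F` gives 16 mL.min-1.g-1, the only outright number among the two values in hand. Compound 1 `COC(C)(C)[C@@H](O)C(=O)N1N=CC[C@H]1C(=O)NCc1cc(Cl)ccc1-n1cnnn1` returns only a limit of the assay, < 12 mL.min-1.g-1. For the measured compounds named here, the single step between measured compounds is an at least 1.3-fold higher number from compound 1 to compound 2 (0.12 log units; that floor lies within the scatter), and because one of its ends sits at the limit of < 12 mL.min-1.g-1 in this assay, at which 1 of the 2 values shown sits, its true size stays open. Compound 3 `CC(C)(C)C[C@@H](O)C(=O)N1N=CC[C@H]1C(=O)NCc1cc(Cl)ccc1-n1cnnn1` differs from compound 2 by neopentyl in place of 2-fluorophenyl on a saturated chain carbon bound to a carbonyl carbon and an oxygen on a saturated carbon. Going by the values given here, no measured step exchanges a 2-fluorophenyl for a neopentyl on a saturated chain carbon bound to a carbonyl carbon and an oxygen on a saturated carbon, and the one step available, 2-fluorophenyl in place of 1-methoxy-1-methylethyl, was itself within the scatter at its floor. Compound 3 is therefore expected to stay close to where its parent stands, the estimated step being a 1.1-fold higher number from compound 2 to compound 3 (0.05 log units; within the scatter). Compound 3 is expected to give 18 mL.min-1.g-1 in this assay, within a range from 8 mL.min-1.g-1 to 40 mL.min-1.g-1.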

Compound 3, intrinsic clearance in microsomes: 22 mL.min-1.g-1
The estimate for compound 3 lay 1.2-fold (0.09 log units) below the measured number; the range from low to high includes it.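

In this assay, among the compounds shown here, neopentyl in place of 2-fluorophenyl gives a 1.4-fold higher number from compound 2 to compound 3 (0.14 log units; within the scatter), so for the first time two outright numbers at this position can be set side by side, and an open chain and a carbon-only aromatic ring do not separate here. For the compounds shown here, with neopentyl in place of 1-methoxy-1-methylethyl, the same position gives an at least 1.8-fold higher number from compound 1 to compound 3 (0.26 log units; that floor lies within the scatter), which is the only reading against that group. On these data alone, compound 1 remains a limit of the assay, and the true size of this step stays open because of it: the limit of < 12 mL.min-1.g-1 in this assay, at which 1 of the 3 values shown sits.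

The compounds shown leave open whether an amine or a carboxylic acid on this saturated chain carbon would carry the number beyond the scatter. They also leave open whether a longer chain than neopentyl would do so.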